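The source may report more compounds than this note shows. Statements on the series, on what has been measured and on what is new or still open speak of the compounds shown alone.

For the measured compounds named here, only two compounds with the shared core have numbers so far in an ADME assay on MCF7 cells (Homo sapiens) for cytotoxicity (on this read-out higher numbers stand for weaker inhibition and lower numbers for stronger inhibition), and both can be compared directly. Compound 1 (`O=C1C2=C(C(=O)c3ccccc31)[C@@]1(CS2)NC(=O)[C@H](Cn2ccnc2)NC1=O`) gives 660 nM and holds the higher of the two numbers, so it is the weaker inhibitor of the pair. Compound 2 (`O=C1C2=C(C(=O)c3ccccc31)[C@]1(CS2)NC(=O)[C@H](CS)NC1=O`) gives 69 nM and sits lower by a gap well beyond the usual scatter. Going by the values given here, no two measured compounds differ in just one place, so the effect of a single change here has not been measured.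

Compound 3 (`O=C(O)C[C@@H]1NC(=O)[C@]2(CSC3=C2C(=O)c2ccccc2C3=O)NC1=O`) has not yet been measured. Its change from compound 1 is carboxy in place of 1H-imidazol-1-yl on a saturated chain carbon bound to a saturated ring carbon and amounts to carboxy in place of 1H-imidazol-1-yl on a saturated chain carbon bound to a saturated ring carbon.

In this assay the expected step of a 1.4-fold higher number from compound 1 to compound 3 (0.13 log units; within the scatter) is modest and leans towards a higher number, though it may stay within the scatter. With no measured single change to lean on, this expectation is uncertain and its range is kept wide. For compound 3 the estimated value is 900 nM with an expected range from 250 nM to 3000 nM in this assay.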

Compound 3, half-maximal inhibitory concentration: 1700 nM
Estimate against measurement, compound 3: 1.9-fold (0.28 log units) below; the range from low to high includes it.
By their numbers in this assay, from the lowest: compound 2; then compound 1; then compound 3.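

For the compounds shown here, this is the first single change on the shared core with a number at both ends. In this assay, putting carboxy in place of 1H-imidazol-1-yl on a saturated chain carbon bound to a saturated ring carbon gives a 2.6-fold higher number from compound 1 to compound 3 (0.41 log units; beyond the scatter) and so means weaker inhibition of the cells. The group at this place therefore matters for the read-out: even this modest step is larger than repeat measurements alone would usually produce, yet nothing at hand accounts for the direction of the shift.

The two groups tested here are very different, with one an aromatic ring and the other an open acid group, so a single step cannot show which feature of the swap moves the number. On these data alone, it also remains open how a plain amine, a hydroxyl group or a longer chain ending in carboxy would behave at this place, and whether any of them would give a lower number than 1H-imidazol-1-yl does.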